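Sulfonyl aryl exchange on the shared core

A few compounds are considered here, and "the series" means these few. Any claim that something is new, unique, unknown or untested is made for them only; others in the source may bear on it.

Measured so far:
compound 1 `CC1CCN(c2c(S(=O)(=O)c3ccc(C#N)cc3)cnc3cc(F)ccc23)CC1` — 83%
compound 2 `Cc1ccc(S(=O)(=O)c2cnc3ccc(F)cc3c2N2CCC(C)CC2)cc1F` — 86%
compound 3 `CC1CCN(c2c(S(=O)(=O)c3ccc(C#N)cc3)cnc3cc(Cl)ccc23)CC1` — 70%

In an assay on isolated protein for displacement of a labelled ligand from metabotropic glutamate receptor 5 (Homo sapiens), with a stated time of 60 min, tested at 1 uM (a higher number here means more inhibition at the concentration tested (going by the name of the read-out), a lower number less inhibition), compound 1 gives 83%, the second highest of the three numbers. Its nearest neighbour is compound 2, which in this assay gives 86%, a gap within the usual scatter. Furthest away is compound 3 with 70%; the step of a number 13 percentage points lower from compound 1 to compound 3 (beyond the scatter) is the only single-point change measured here, and it concerns a halogen on the core, not the aryl group on the sulfonyl sulfur.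

Compound 4 `Cc1ccc(S(=O)(=O)c2cnc3cc(F)ccc3c2N2CCC(C)CC2)cc1F` is not yet measured. It differs from compound 1 as follows: 3-fluoro-4-methylphenyl in place of 4-cyanophenyl on a sulfonyl sulfur. Among the measured compounds shown here, no measured step isolates this exchange. Compound 2 carries the same 3-fluoro-4-methylphenyl on the sulfonyl sulfur as compound 4, but also differs from compound 1 in the position of the fluoro on the core, so it does not give a clean step; its value and that of compound 1 nevertheless lie within the scatter of each other. For the measured compounds named here, nothing among the measured compounds points to a shift beyond the scatter for this change. The step of a number 1 percentage points higher from compound 1 to compound 4 (within the scatter) is therefore expected to be small. For compound 4 an inhibition of about 84% is estimated, within 72% to 94%.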

Compound 4, a percentage reported as inhibition, at one concentration (the size of the read-out at that concentration, not a potency): 89%
Estimate against measurement, compound 4: 5 percentage points below; measured number inside the range.
By their numbers in this assay, from the lowest: compound 3; then compounds 1, 2 and 4 (each within the scatter of the next).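

In this assay, among the compounds shown here, a number 6 percentage points higher from compound 1 to compound 4 (within the scatter) is the first clean reading of 3-fluoro-4-methylphenyl in place of 4-cyanophenyl on a sulfonyl sulfur, with the rest of the structure held constant. Compound 2 could not give this reading, as it also differs from compound 1 in where the fluoro sits on the core. The new step shows that, at the single concentration tested, this position accepts the exchange of a nitrile-bearing aryl group for a fluoro- and methyl-bearing one without a shift beyond the scatter, although this is one exchange and not a trend across aryl groups, and no measurement here explains the result.

Two aryl groups on the sulfonyl sulfur say little about how this position would respond to a non-aromatic group such as a longer alkyl chain, or to an aryl group carrying an amine or a carboxylic acid. As far as these compounds go, because the read-out is a percentage at one concentration and not a potency, any difference between compound 1 and compound 4 that a full concentration-response measurement might show also remains open.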